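Dichlorophenyl swap transferred from alkyne to saturated chain

The source may report more compounds than this note shows. Statements on the series, on what has been measured and on what is new or still open speak of the compounds shown alone.

Compound 1 `O=C(CCCCC#Cc1ccc(Cl)cc1)c1ncc(-c2ccccn2)o1` and compound 2 `O=C(CCCCC#Cc1cccc(Cl)c1Cl)c1ncc(-c2ccccn2)o1` share a core and differ only in the aryl group on the alkyne. In an assay for inhibition of Fatty-acid amide hydrolase 1 (Rattus norvegicus) (on this read-out lower numbers stand for stronger inhibition and higher numbers for weaker inhibition), compound 1 gives 20 nM, while compound 2 gives 5 nM. The change 2,3-dichlorophenyl in place of 4-chlorophenyl on a triple-bonded carbon thus produced a step of a 4.0-fold lower number from compound 1 to compound 2 (0.60 log units; beyond the scatter).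

Compound 3 `O=C(CCCCCCc1ccc(Cl)cc1)c1ncc(-c2ccccn2)o1` carries the 4-chlorophenyl group on a saturated chain instead; in this assay compound 3 gives 2.7 nM. Compound 3 and compound 1 differ in more than one place, so the difference between the two cores is not broken down here. The values of compound 3 and compound 2 lie within the usual scatter of each other, so no order between them is claimed.

Compound 4 `O=C(CCCCCCc1cccc(Cl)c1Cl)c1ncc(-c2ccccn2)o1` has not been measured. It differs from compound 3 by 2,3-dichlorophenyl in place of 4-chlorophenyl on a saturated chain carbon, six bonds along the chain from a carbonyl carbon. The surroundings of the change are not identical to those of the earlier pair: there the new group sat on a triple-bonded carbon whose other neighbour is a triple-bonded carbon, here it sits on a saturated chain carbon, six bonds along the chain from a carbonyl carbon. It is therefore the same kind of change, not the same change.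

Going by the values given here, for compound 4 a step of a 2.7-fold lower number from compound 3 to compound 4 (0.43 log units; beyond the scatter) is expected, set beside the earlier step, because the only measured instance of this change, a 4.0-fold lower number from compound 1 to compound 2 (0.60 log units; beyond the scatter), was modest and compound 3 already gives 2.7 nM. Compound 4 is estimated at 1 nM, with a range of 0.4 nM to 3 nM.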

Compound 4, inhibition constant: 0.9 nM
The estimate for compound 4 lay 1.1-fold (0.05 log units) above the measured number, and the stated range covers the measured number.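

In this assay, 2,3-dichlorophenyl in place of 4-chlorophenyl on a saturated chain carbon gives a 3.0-fold lower number from compound 3 to compound 4 (0.48 log units; beyond the scatter), so the change that lowered the number on the alkyne core also lowers it on the saturated chain core. The two steps point the same way and cannot be told apart in size, which is what carrying the change from one core to the other would look like in this series: the same change on two cores in this assay, a 4.0-fold lower number (0.60 log units; beyond the scatter) from compound 1 to compound 2 and a 3.0-fold lower number (0.48 log units; beyond the scatter) from compound 3 to compound 4, 1.3-fold (0.12 log units) apart, within the scatter of two such steps This agreement rests on two pairs that differ only in the triple bond of the chain, so it shows neither why the change lowers the number nor that it would hold on any core further removed from these two.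

Still open, on these data alone, is whether the step belongs to the added chlorine or to its new placing on the ring, a question that a 2-chlorophenyl or a 3-chlorophenyl group on the same chain would help to separate. Also open, as far as these compounds go, is whether the step survives a shorter or longer chain, or a ring carrying a different group such as trifluoromethyl, methoxy or a carboxylic acid in place of chlorine.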